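Methyl on the oxetane ring of compound 1: series notes

This account rests on a few compounds, and the source may have more. Where it says the series, first, only, none or still open, it means among the compounds named here.

Of the compounds shown here, three share the core and have been measured in an assay on isolated protein for inhibition of aldehyde dehydrogenase 1A1 (Homo sapiens); a higher number here means a weaker inhibitor, a lower number a stronger inhibitor. Compound 1 `CC(Sc1nc2nn(C3COC3)cc2c(=O)n1-c1ccccc1)c1ccccc1` gives 109 nM and stands lowest of the three. Compound 3 `Cn1ncc2c(=O)n(-c3ccccc3)c(SC(C)(C)c3ccccc3)nc21` gives 1900 nM; compound 2 `CC(Oc1nc2c(cnn2C)c(=O)n1-c1ccccc1)c1ccccc1` gives 2400 nM. Both of these lie beyond the scatter from compound 1, so compound 1 is the strongest inhibitor measured so far. No two of the measured compounds differ in one place only, so no single step can be read from them.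

Compound 4 `CC(Sc1nc2nn(C3(C)COC3)cc2c(=O)n1-c1ccccc1)c1ccccc1` is not yet measured. It differs from compound 1 by methyl in place of hydrogen on a saturated ring carbon, oxetan-3-yl becoming 3-methyloxetan-3-yl. Going by the values given here, the measured set gives no step for a change of this kind, so the expectation rests on compound 1 alone. A step of a 1.4-fold higher number from compound 1 to compound 4 (0.14 log units; within the scatter) is expected, roughly within the scatter or slightly weaker. Compound 4 is therefore estimated at 150 nM, with a range from 50 nM to 450 nM.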

Compound 4, half-maximal inhibitory concentration: 93 nM
For compound 4 the middle estimate is 1.6-fold (0.21 log units) above the measured one; measured number inside the range.
By their numbers in this assay, from the lowest: compounds 4 and 1 (each within the scatter of the next); then compounds 3 and 2 (each within the scatter of the next).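

In this assay methyl in place of hydrogen on this saturated ring carbon, two ring bonds from the ring oxygen, gives a 1.2-fold lower number from compound 1 to compound 4 (0.07 log units; within the scatter) and so leaves oxetan-3-yl and 3-methyloxetan-3-yl indistinguishable in this read-out. Going by these compounds alone, this is the only single-place step so far, and it shows that this ring carbon can carry one added methyl with no change beyond the scatter. Nothing at hand bears on why the number holds at this position.

Still open, on these data alone, is whether the same ring carbon accepts anything larger than methyl, such as ethyl, hydroxymethyl or aminomethyl, and whether cyclobutyl in place of the oxetane ring would read the same. Also open, as far as these compounds go, is whether this methyl step would repeat with other groups elsewhere on the shared core.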